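The compounds below may be only part of what the source reports. "The series", "measured", "known", "first", "only" and "open" are said of these compounds alone.

Measured so far:
- compound 1 `Cc1ccc(OCC(=O)N(CCCO)Cc2cccs2)cc1`: 3000 nM
- compound 2 `Cc1ccc(OCC(=O)N(Cc2cccs2)c2ccn[nH]2)cc1`: 0.2 nM
- compound 3 `Cc1ccc(OCC(=O)N(Cc2cccs2)c2ccn(C)n2)cc1`: 855 nM

All three numbers come from an assay on HEK293 cells for agonist activity at transient receptor potential cation channel subfamily M member 8 (Homo sapiens), read by fluorescence and calcium flux, with a stated time of 15 min; a higher number here means that more compound is needed for the effect, a lower number that less compound is needed. Among them compound 3 stands second highest: its nearest neighbour is compound 1, and the two differ by a 3.5-fold lower number from compound 1 to compound 3 (0.55 log units; beyond the scatter), while the gap to compound 2 is much wider, a 4300-fold higher number from compound 2 to compound 3 (3.63 log units; beyond the scatter).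

Compound 4 `Cc1ccc(OCC(=O)N(Cc2cccs2)c2nccs2)cc1` is the next candidate. It differs from compound 3 in one place: 1,3-thiazol-2-yl in place of 1-methyl-1H-pyrazol-3-yl on an amide-type nitrogen.

Among the measured compounds shown here, every measured step so far swaps the group on this same amide-type nitrogen, and the outcomes span a huge range: a 15000-fold lower number from compound 1 to compound 2 (4.18 log units; beyond the scatter), a 3.5-fold lower number from compound 1 to compound 3 (0.55 log units; beyond the scatter) and a 4300-fold higher number from compound 2 to compound 3 (3.63 log units; beyond the scatter). So the group on this nitrogen clearly matters a great deal in this assay, but no measured step brings in a 1,3-thiazol-2-yl, and nothing here shows whether it behaves more like the group in compound 2 or like that in compound 3. The expectation is therefore uncertain in size and leans only slightly toward a lower number, an estimated 8.6-fold lower number from compound 3 to compound 4 (0.93 log units; beyond the scatter) for compound 4. On that basis compound 4 is estimated at 100 nM, with an expected range from 5 nM to 2000 nM.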

Compound 4, half-maximal effective concentration: 2240 nM
Beside the measured number, compound 4's estimate is 22-fold (1.35 log units) below it; measured number outside the range, above it.
By their numbers in this assay, from the lowest: compound 2; then compound 3; then compounds 4 and 1 (each within the scatter of the next).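

Replacing the 1-methyl-1H-pyrazol-3-yl with a 1,3-thiazol-2-yl on the amide-type nitrogen gives a 2.6-fold higher number from compound 3 to compound 4 (0.42 log units; beyond the scatter) in this assay, and the gap to the most potent compound remains very wide, with an 11000-fold higher number from compound 2 to compound 4 (4.05 log units; beyond the scatter) as the step. So a second five-membered aromatic ring with 2 hetero atoms and 0 hydrogen-bond donors does not recover the very low number of compound 2, and the result also gives a 1.3-fold lower number from compound 1 to compound 4 (0.13 log units; within the scatter) as the step, which leaves compound 4 indistinguishable from the open-chain 3-hydroxypropyl compound, so an aromatic ring on this nitrogen is not enough on its own. Nothing measured here explains why these rings differ so sharply.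

Compound 2 is the only compound shown with a hydrogen on a ring nitrogen, so it remains open whether that hydrogen matters, and a 1H-imidazol-2-yl, a 1H-1,2,4-triazol-3-yl or a plain phenyl ring on this nitrogen would help to test this. It is also open whether the same order among these groups would hold if the rest of the shared core were changed.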